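A few compounds are considered here, and "the series" means these few. Any claim that something is new, unique, unknown or untested is made for them only; others in the source may bear on it.

Notes on the series. Compound 1 `CCCn1c(-c2ccc(O)cc2)c(C)c2ccccc21` carries a propyl chain on the ring nitrogen and a hydroxy on the pendant phenyl; in a functional assay on MSTO-211H cells (Homo sapiens) for inhibition, read by trypan blue exclusion, with a stated time of 72 h (a higher number here means a weaker inhibitor of growth, a lower number a stronger inhibitor of growth), compound 1 gives 7100 nM. Among the compounds with values here, compound 2 `CCCn1c(-c2ccc(O)cc2)c(C)c2cc(O)ccc21` adds a hydroxy to the bicyclic core and in this assay compound 2 gives 2900 nM; the change a 2.4-fold lower number from compound 1 to compound 2 (0.39 log units; beyond the scatter) is the only measured step so far, and on the two numbers known compound 2 stands lowest, with compound 1 the only comparator.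

Compound 3 `CCCn1c(-c2ccc(O)c(O)c2)c(C)c2cc(O)ccc21` differs from compound 2 by hydroxy in place of hydrogen on an aromatic carbon. Within the data shown here, no measured step bears directly on a hydroxy entering on the pendant phenyl; the only precedent is a 2.4-fold lower number from compound 1 to compound 2 (0.39 log units; beyond the scatter), which placed the hydroxy elsewhere and was modest. A step of similar or smaller size in this assay is therefore expected, toward a lower number, with real uncertainty about whether it clears the scatter. For compound 3 the estimate is 2000 nM, range 800 nM to 5000 nM, which means an expected step of a 1.5-fold lower number from compound 2 to compound 3 (0.16 log units; within the scatter).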

Compound 3, concentration for 50% growth inhibition: > 20000 nM
Compound 3 gave a limit, no number; the forecaster's own chance of this, stated with the estimate: 5%; at least 10-fold (1.00 log units) between middle value and limit.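

On the pendant phenyl, ortho to a hydroxy group, the added hydroxy moves the read-out of this assay the opposite way: the result is an at least 6.8-fold higher number from compound 2 to compound 3 (0.83 log units; beyond the scatter), whereas the hydroxy added to the shared core gave a 2.4-fold lower number from compound 1 to compound 2 (0.39 log units; beyond the scatter). The same change therefore has no single direction across these two steps, and its outcome depends on where it is placed. Compound 3 is a limit of the assay and not a number, so the full size of its step stays unknown: the limit of > 20000 nM in this assay, at which 1 of the 3 values shown sits.

The compounds shown leave open whether the weaker growth inhibition belongs to this position itself or to the two neighbouring hydroxy groups together. A methoxy or a fluorine at this position, or the same hydroxy on the core of compound 1, would separate these readings.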